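A few compounds are considered here, and "the series" means these few. Any claim that something is new, unique, unknown or untested is made for them only; others in the source may bear on it.

In an ADME assay on RAW264.7 cells (Mus musculus) for cytotoxicity, read by MTT assay, with a stated time of 72 h, tested at 50 ug/mL (on this read-out higher numbers stand for more inhibition at the one concentration tested (going by the name of the read-out) and lower numbers for less inhibition), three compounds of a shared core have been measured. Compound 1, `O=C(c1nc2cc(Cl)ccc2s1)N1CCN(c2cnccn2)CC1`, gives 54.9%. Compound 2, `O=C(c1nc2cc(C(F)(F)F)ccc2s1)N1CCN(c2cnccn2)CC1`, gives 28.1%. Compound 3, `CCOC(=O)c1nc2cc(Cl)ccc2s1`, gives 37.4%. The gap between compound 2 and compound 3 lies within the usual scatter of this kind of measurement, so the two cannot be ranked; the gap to compound 1 lies beyond it, and that single step was a number 26.8 percentage points lower from compound 1 to compound 2 (beyond the scatter).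

Compound 4, `O=C(c1nc2cc(C(F)(F)F)ccc2s1)N1CCN(c2ccncc2)CC1`, differs from compound 2 in one place: pyridin-4-yl in place of pyrazin-2-yl on an amine nitrogen in a ring. None of the measured steps touches this part of the structure; the only step shown concerns a trifluoromethyl in place of chloro on an aromatic carbon, which compound 4 keeps unchanged from compound 2. There is therefore no measured guide for a change on the amine nitrogen in the ring, and the plain expectation is a step that stays within the scatter.

On that basis compound 4 is expected to give 30%, with a range from 15% to 45%, which means an expected step of a number 1.9 percentage points higher from compound 2 to compound 4 (within the scatter).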

Compound 4, a percentage reported as inhibition, at one concentration (the size of the read-out at that concentration, not a potency): 17.5%
Beside the measured number, compound 4's estimate is 12.5 percentage points above it, and the stated range covers the measured number.
By their numbers in this assay, from the lowest: compound 4; then compounds 2 and 3 (each within the scatter of the next); then compound 1.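

In this assay, the group on the amine nitrogen in the ring turns out to matter: with pyridin-4-yl in place of pyrazin-2-yl, the step is a number 10.6 percentage points lower from compound 2 to compound 4 (beyond the scatter). Going by these compounds alone, the only step available before this one lay on an aromatic carbon of the shared core, so this is the first sign that the read-out also moves with a change at this second place, even though both groups are six-membered aromatic rings with the same count of heavy atoms and differ in having 2 nitrogen or 1 nitrogen. Nothing shown here speaks to the reason for this step.

Among the compounds shown, this place carries only these two rings, both alongside the trifluoromethyl group, so it remains open whether the same swap would give a similar step with chloro in place of trifluoromethyl. Going by these compounds, it also remains open how the read-out would respond to a phenyl ring, which has no ring nitrogen, or to a simple ethyl chain on that amine nitrogen.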